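Compound 3 to compound 4 among limits

The source may report more compounds than this note shows. Statements on the series, on what has been measured and on what is new or still open speak of the compounds shown alone.

- Compound 1 `CS(=O)(=O)Cc1nc2c(Sc3ccc(Cl)cc3)cc(Cl)cn2c1[N+](=O)[O-]`: > 31200 nM, a limit
- Compound 2 `O=[N+]([O-])c1cnc2c(Sc3ccc(Cl)cc3)cc(Cl)cn12`: > 7800 nM, a limit
- Compound 3 `O=[N+]([O-])c1c(CSc2ccccc2)nc2c(Sc3ccc(Cl)cc3)cc(Cl)cn12`: > 15600 nM, a limit

All three values come from an ADME assay on HepG2 cells (Homo sapiens) for cytotoxicity, read by MTT assay, with a stated time of 72 h (a lower number here means that less compound is tolerated, a higher number that more compound is tolerated), and none is a number proper. Compound 3 therefore stands only at its limit of > 15600 nM. In compound 4 `O=[N+]([O-])c1c(CS(=O)(=O)C2CCCCC2)nc2c(Sc3ccc(Cl)cc3)cc(Cl)cn12`, cyclohexylsulfonyl replaces phenylsulfanyl on a saturated chain carbon bound to an aromatic carbon (cyclohexylsulfonyl in place of phenylsulfanyl on a saturated chain carbon bound to an aromatic carbon). The closest measured change, at the same place, is a step that the two limits leave unreadable from compound 1 to compound 3. Also relevant is a step that the two limits leave unreadable from compound 2 to compound 3. Neither gives a size to carry over, so no step beyond the scatter is expected in this assay. The expected change is a step that the limit leaves unreadable from compound 3 to compound 4. Compound 4 is estimated at 20000 nM, with an expected range from 8000 nM to 50000 nM, and may well be reported as a limit again.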

Compound 4, half-maximal cytotoxic concentration: > 31200 nM
Compound 4: only a limit was reported; the forecaster's own chance of this, stated with the estimate: 85%; at least 1.5-fold (0.19 log units) between middle value and limit.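

In this assay compound 4 gives > 31200 nM, which is a limit. Its steps to compound 1, compound 2 and compound 3 cannot be read. The compounds shown leave open the actual half-maximal cytotoxic concentration of each, and whether these groups change it at all.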